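Compound 3 and a longer selenocyanate chain

This account rests on a few compounds, and the source may have more. Where it says the series, first, only, none or still open, it means among the compounds named here.

Measured so far in a functional assay on LoVo cells (Homo sapiens) for inhibition, read by MTT assay, with a stated time of 48 h (a lower number here means a stronger inhibitor, a higher number a weaker inhibitor), for two compounds:
Compound 1 `COc1ccc(N(C)c2nc(C)nc3ccccc23)cc1C(=O)OCCCC[Se]C#N`: 1080 nM
Compound 2 `COc1ccc(N(C)c2nc(C)nc3ccccc23)cc1C[Se]C#N`: 277 nM

Compound 2 holds the lower number of the pair, with 277 nM against the higher value of compound 1. Compound 3 `COc1ccc(N(C)c2nc(C)nc3ccccc23)cc1OCCCCC[Se]C#N` has yet to be measured. It carries a group of 9 heavy atoms (6 carbon, 1 nitrogen, 1 oxygen, 1 selenium; no ring) in place of a group of 4 heavy atoms (2 carbon, 1 nitrogen, 1 selenium; no ring), on an aromatic carbon ortho to a methoxy group. Going by the values given here, one measured step bears on this change: a 3.9-fold lower number from compound 1 to compound 2 (0.59 log units; beyond the scatter) came as a larger group gave way to a smaller one. The move to compound 3 runs the opposite way, so a rise of similar size is expected in this assay too. The two larger groups are not identical, however, and a single step offers thin support. The expected change is a 2.9-fold higher number from compound 2 to compound 3 (0.46 log units; beyond the scatter) by this estimate. Compound 3 is expected at 800 nM with an estimated range from 300 nM to 2200 nM for the coming measurement.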

Compound 3, half-maximal inhibitory concentration: 5210 nM
Estimate against measurement, compound 3: 6.5-fold (0.81 log units) below; the measured number lies above the stated range.
By their numbers in this assay, from the lowest: compound 2; then compound 1; then compound 3.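

In this assay, a 19-fold higher number from compound 2 to compound 3 (1.27 log units; beyond the scatter) shows that this place on the aromatic carbon, ortho to a methoxy group, responds far more strongly to the larger selenocyanate group than the earlier pair suggested. Size alone does not order the three compounds: a 4.8-fold higher number from compound 1 to compound 3 (0.68 log units; beyond the scatter) accompanies a change from the group of 10 heavy atoms to the group of 9, so compound 1, with the largest group, goes against any simple rule that a larger group gives a higher number. No measurement here explains this difference between the groups.

The compounds shown leave open how the number moves with the length of the chain when an ether oxygen links it to the ring. Going by these compounds, it also remains open how an amide link, or a thiocyanate end with sulfur in place of selenium, would compare.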